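The source may hold more compounds than are shown below. What is called first, only, known or untested is meant among the compounds shown, and "the series" means these compounds.

Measured so far:
compound 1, `NC(=O)C1CCN(c2cc3c(cc2F)c(=O)c(C(=O)NCc2ccco2)cn3C2CC2)CC1`, > 100000 nM
compound 2, `CCCCn1cc(C(=O)NCc2ccc(OC)cc2)c(=O)c2cc(F)c(N3CCC(C(N)=O)CC3)cc21`, 40800 nM
compound 3, `CCCCn1cc(C(=O)NCc2ccco2)c(=O)c2cc(F)c(N3CCC(C(N)=O)CC3)cc21`, 41400 nM

All three were tested in an ADME assay on J774.1 cells (Mus musculus) for cytotoxicity, read by resazurin assay, with a stated time of 48 h; a higher number here means a weaker inhibitor, a lower number a stronger inhibitor. For compound 1 the value is a limit of the assay rather than a number. Compound 2 and compound 3 share the same core and differ only by 4-methoxyphenyl in place of furan-2-yl on a saturated chain carbon bound to an amide-type nitrogen; the step of a 1.0-fold higher number from compound 2 to compound 3 (0.01 log units; within the scatter) shows that their two values sit together. Compound 3 and compound 1 differ by cyclopropyl in place of butyl on an aromatic nitrogen, and here the step of an at least 2.4-fold higher number from compound 3 to compound 1 (0.38 log units; beyond the scatter) is at least modest, its full size unknown because compound 1 sits at the limit of > 100000 nM in this assay, at which 1 of the 3 values shown sits.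

Compound 4, `COc1ccc(CNC(=O)c2cn(C3CC3)c3cc(N4CCC(C(N)=O)CC4)c(F)cc3c2=O)cc1`, has not yet been measured. It differs from compound 2 by cyclopropyl in place of butyl on an aromatic nitrogen, the same kind of change as from compound 3 to compound 1, though the surroundings are not identical: in compound 2 the aromatic nitrogen is meta to a (4-methoxybenzyl)carbamoyl group, whereas in compound 3 it is meta to a ((furan-2-yl)methyl)carbamoyl group. The step expected is a 2.5-fold higher number from compound 2 to compound 4 (0.39 log units; beyond the scatter), resting on the size of an at least 2.4-fold higher number from compound 3 to compound 1 (0.38 log units; beyond the scatter). Compound 4 is therefore expected to give about 100000 nM, within 45000 nM to 250000 nM, and may register only as a limit.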

Compound 4, half-maximal inhibitory concentration: > 100000 nM
Compound 4 ended at the assay's limit (the forecaster's own chance of this, stated with the estimate: 60%); the middle value sits exactly at the limit.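

In this assay compound 4 gives > 100000 nM, which is a limit of the assay and not a number. Cyclopropyl in place of butyl on the aromatic nitrogen gives an at least 2.4-fold higher number from compound 2 to compound 4 (0.38 log units; beyond the scatter), so with 4-methoxyphenyl on the amide side the change points the same way as it does with furan-2-yl, and in both cases it goes beyond the scatter. This shows that the direction carries from one core to the other in these two pairs, but not that the size does: the same change on two cores in this assay, an at least 2.4-fold higher number (0.38 log units; beyond the scatter) from compound 3 to compound 1 and an at least 2.4-fold higher number (0.38 log units; beyond the scatter) from compound 2 to compound 4; the limit leaves it open whether they differ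

On these data alone, the step between compound 1 and compound 4 cannot be read, since both stand as limits, so any effect of swapping furan-2-yl for 4-methoxyphenyl when cyclopropyl is present remains open. Also open, as far as these compounds go, is where the values would fall with another group on the aromatic nitrogen, such as an ethyl or a longer hexyl chain, and whether such values would stay clear of the limit.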